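The source may report more compounds than this note shows. Statements on the series, on what has been measured and on what is new or still open speak of the compounds shown alone.

Compound 1 `COc1cc(-c2nn(-c3cccc(NC(=O)Nc4cc(C(F)(F)F)cc(C(F)(F)F)c4)c3)cc2-c2ccncc2)ccc1Cl` and compound 2 `COc1cc(-c2nn(-c3cccc(NC(=O)Nc4ccc(Cl)c(Cl)c4)c3)cc2-c2ccncc2)ccc1Cl` share one core, and the difference between them is not broken down here. In a functional assay on NCI-H460 cells (Homo sapiens) for inhibition, read by sulforhodamine B assay, with a stated time of 48 h (a higher number here means a weaker inhibitor of growth, a lower number a stronger inhibitor of growth), compound 1 gives 558 nM and compound 2 gives 1110 nM; the two numbers lie within the scatter of each other. Compound 3 `O=C(Nc1cccc(-n2cc(-c3ccncc3)c(-c3ccc(Cl)c(O)c3)n2)c1)Nc1ccc(Cl)c(Cl)c1` is compound 2 with hydrogen in place of methyl on an oxygen on an aromatic ring. In this assay compound 3 gives 993 nM, a step of a 1.1-fold lower number from compound 2 to compound 3 (0.05 log units; within the scatter). Compound 4 `O=C(Nc1cccc(-n2cc(-c3ccncc3)c(-c3ccc(Cl)c(O)c3)n2)c1)Nc1cc(C(F)(F)F)cc(C(F)(F)F)c1` carries the same change made on compound 1: hydrogen in place of methyl on an oxygen on an aromatic ring. The place of the change reads the same in both pairs, so this is the same change on two cores that differ elsewhere in the urea part. Since the step from compound 2 to compound 3 stayed within the scatter, the expectation is that compound 4 will also stay close to compound 1, with a step of about a 1.1-fold lower number from compound 1 to compound 4 (0.03 log units; within the scatter) expected in this assay. The number for compound 4 is therefore estimated at 520 nM, and most likely between 250 nM and 1100 nM because compound 1 gives 558 nM and the change did little in the one case seen.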

Compound 4, concentration for 50% growth inhibition: 413 nM
Estimate against measurement, compound 4: 1.3-fold (0.10 log units) above; the range from low to high includes it.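

Going from methoxy to hydroxy on the core of compound 1 stays within the scatter in this assay, with a 1.4-fold lower number from compound 1 to compound 4 (0.13 log units; within the scatter). Set beside the earlier case, the same change reads alike on the two cores, which differ in the urea part, and no difference between the two steps can be told apart: the same change on two cores in this assay, a 1.1-fold lower number (0.05 log units; within the scatter) from compound 2 to compound 3 and a 1.4-fold lower number (0.13 log units; within the scatter) from compound 1 to compound 4, 1.2-fold (0.08 log units) apart, within the scatter of two such steps. This shows that, in these two pairs, the change can be carried from one core to the other with little effect on the number, but two small steps do not show that it would hold on other cores, and they do not explain why the methoxy and hydroxy compounds read alike.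

The compounds shown leave open whether a longer chain on that oxygen, or an amine in place of the hydroxy, would give a step beyond the scatter. As far as these compounds go, it also remains open whether the step would stay this small with a nitrile on the urea part.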